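Amide aryl swap from chloropyridinyl to chlorophenyl

The source may hold more compounds than are shown below. What is called first, only, known or untested is meant among the compounds shown, and "the series" means these compounds.

Measured compounds:
- compound 1, `O=C(CCCl)Nc1ccc(SCC(=O)Nc2cc(Cl)ccn2)cc1`: in a functional assay on A875 cells (Homo sapiens) for antiproliferative activity, read by MTT assay, with a stated time of 48 h (a higher number here means a weaker inhibitor, a lower number a stronger inhibitor), compound 1 gives 12300 nM.
- compound 2, `CC(C)(C)C(=O)Nc1ccc(SCC(=O)Nc2cc(Cl)ccn2)cc1`: in this assay compound 2 reaches only a limit of the assay, > 80000 nM, and no number.
- compound 3, `C=CC(=O)Nc1ccc(SCC(=O)Nc2cc(Cl)ccn2)cc1`: in this assay compound 3 gives 14700 nM.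

Compound 3 holds the higher of the two numbers measured in this assay; compound 1 lies nearest, and the step of a 1.2-fold higher number from compound 1 to compound 3 (0.08 log units; within the scatter) stays within the scatter. Compound 2 stands at a limit (the limit of > 80000 nM in this assay, at which 1 of the 3 values shown sits). Every step measured so far changes the group on the carbonyl carbon: an at least 6.5-fold higher number from compound 1 to compound 2 (0.81 log units; beyond the scatter) and an at least 5.4-fold lower number from compound 2 to compound 3 (0.73 log units; beyond the scatter) show that side of the shared core matters, while the other side has not been varied.

Compound 4, `C=CC(=O)Nc1ccc(SCC(=O)Nc2cccc(Cl)c2)cc1`, differs from compound 3 on that untested side: 3-chlorophenyl in place of 4-chloropyridin-2-yl on an amide-type nitrogen. Within the data shown here, none of the measured steps bears on this position, so they give no direct guide to its size or direction. With no guide, compound 4 is expected to lie close to compound 3, with an estimated step of a 1.0-fold higher number from compound 3 to compound 4 (0.01 log units; within the scatter), and a wide range is kept. In this assay compound 4 is estimated at 15000 nM, between 4000 nM and 60000 nM.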

Compound 4, half-maximal inhibitory concentration: 21100 nM
Compound 4: middle estimate off by 1.4-fold (0.15 log units), on the low side; measured number inside the range.
By their numbers in this assay, from the lowest: compounds 1, 3 and 4 (each within the scatter of the next). At a limit, above all of these: compound 2.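

In this assay, among these compounds, the first change on the amide-nitrogen side of the shared core gives a 1.4-fold higher number from compound 3 to compound 4 (0.16 log units; within the scatter) and so stays within the scatter. At this place, on an amide-type nitrogen, 3-chlorophenyl and 4-chloropyridin-2-yl cannot be told apart on this read-out, so the ring nitrogen of 4-chloropyridin-2-yl is not shown to be required. The step on the carbonyl side, an at least 5.4-fold lower number from compound 2 to compound 3 (0.73 log units; beyond the scatter) and beyond the scatter, remains the only clear difference in the series, and nothing measured here explains the new step.

Still open, going by these compounds, is whether a phenyl without chlorine, or a ring carrying a carboxylic acid or an amine, would move the number beyond the scatter at this nitrogen. Also open, on these data alone, is whether the same swap behaves alike with 2-chloroethyl on the carbonyl carbon.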